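The source may hold more compounds than are shown below. What is called first, only, known or untested is meant among the compounds shown, and "the series" means these compounds.

Measured compounds in an ADME assay on BHK cells (Mesocricetus auratus) for cytotoxicity, read by MTT assay, with a stated time of 96 h; a higher number here means that more compound is tolerated, a lower number that less compound is tolerated:

compound 1, `O=C(O)CCC(=O)Nc1ccc(-c2nc3cc(C(F)(F)F)ccc3[nH]2)cc1`, gives > 100000 nM, a limit of the assay rather than a number.
compound 2, `CCN(CC)CC(=O)Nc1ccc(-c2nc3cc(C(F)(F)F)ccc3[nH]2)cc1`, gives 23000 nM.

Going by the values given here, compound 2 holds the only number in this assay; the one further value is the limit of compound 1. Among the compounds with values here, the single measured step, an at least 4.3-fold lower number from compound 1 to compound 2 (0.63 log units; beyond the scatter), shows that a change at this position can move the number by at least a modest amount, with the evidence resting on (the limit of > 100000 nM in this assay, at which 1 of the 2 values shown sits).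

Compound 3, `O=C(CCl)Nc1ccc(-c2nc3cc(C(F)(F)F)ccc3[nH]2)cc1`, differs from compound 2 by chloro in place of diethylamino on a saturated chain carbon bound to a carbonyl carbon. Neither side of the measured step carries chloro, so that step gives the size a substituent change here can reach but not the direction for compound 3. Within the data shown here, nothing among the measured compounds speaks for a step beyond the scatter in either direction, though the possibility of at least a modest move is open on the strength of the step from compound 1 to compound 2.

The expected step for compound 3 is therefore a 1.9-fold lower number from compound 2 to compound 3 (0.28 log units; within the scatter), and the estimated value of compound 3 in this assay is 12000 nM, within a range from 3000 nM to 50000 nM.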

Compound 3, half-maximal cytotoxic concentration: 22000 nM
Compound 3: middle estimate off by 1.8-fold (0.26 log units), on the low side; low and high end bracket the measured number.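

In this assay, the exchange of diethylamino for chloro on a saturated chain carbon bound to a carbonyl carbon gives a 1.0-fold lower number from compound 2 to compound 3 (0.02 log units; within the scatter), so the number does not separate these two groups, although they share little beyond having no ring and no net charge. Going by these compounds alone, compound 1 now stands apart from both other compounds, with an at least 4.5-fold lower number from compound 1 to compound 3 (0.65 log units; beyond the scatter) alongside an at least 4.3-fold lower number from compound 1 to compound 2 (0.63 log units; beyond the scatter), and the only steps beyond the scatter in this short series are those that start from carboxymethyl. Compound 1 carries a limit rather than a number, so both of these steps give only a minimum size: the limit of > 100000 nM in this assay, at which 1 of the 3 values shown sits.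

Still open, going by these compounds, is whether the separation belongs to carboxymethyl alone or would recur with a plain methyl, a primary amine or a carboxylic acid on a longer chain at the same place. Also open is whether the level shared by compound 2 and compound 3 in this assay is set by the shared core, which stays unchanged in all the compounds shown.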